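Pyridinone esters against matrix metalloproteinase-9: a fluoro moved

The source may report more compounds than this note shows. Statements on the series, on what has been measured and on what is new or still open speak of the compounds shown alone.

Measured so far:
compound 1, `O=C(OCc1ccccc1)c1cccc(=O)[nH]1`: 69000 nM
compound 2, `O=C(OCc1ccccc1Br)c1cccc(=O)[nH]1`: 59000 nM
compound 3, `O=C(OCc1ccc(F)cc1)c1cccc(=O)[nH]1`: 3000 nM

All three share one core, a benzyl ester of a pyridinone acid, and differ only in what sits on the benzyl ring. In an assay on isolated protein for inhibition of matrix metalloproteinase-9 (Homo sapiens) (on this read-out lower numbers stand for stronger inhibition and higher numbers for weaker inhibition), compound 1 gives the highest number of the three, with compound 2 nearest and compound 3 furthest away. The step of a 1.2-fold lower number from compound 1 to compound 2 (0.07 log units; within the scatter) shows that a bromo added in place of a hydrogen leaves the read-out where it was. The step of a 23-fold lower number from compound 1 to compound 3 (1.36 log units; beyond the scatter), by contrast, is a large gain from a single fluoro.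

Compound 4, `O=C(OCc1cccc(F)c1)c1cccc(=O)[nH]1`, has not yet been tested in this assay. It differs from compound 1 by fluoro in place of hydrogen on an aromatic carbon. For the measured compounds named here, compound 3 also carries a fluoro on this ring, though not at the same carbon, so the only step that truly bears on the change is the one to compound 3, and it was large. Whether a fluoro at the new place repeats that gain is not known from the data; the bromo of compound 2 warns that not every added halogen helps. The expectation is therefore a step of a 4.6-fold lower number from compound 1 to compound 4 (0.66 log units; beyond the scatter), smaller than the gain seen with compound 3 but in the same direction. Compound 4 is estimated at 15000 nM, with a range from 3000 nM to 69000 nM.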

Compound 4, half-maximal inhibitory concentration: 50000 nM
Compound 4: middle estimate off by 3.3-fold (0.52 log units), on the low side; the measured number falls inside the stated range.
By their numbers in this assay, from the lowest: compound 3; then compounds 4, 2 and 1 (each within the scatter of the next).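

In this assay, the step of a 1.4-fold lower number from compound 1 to compound 4 (0.14 log units; within the scatter) shows that a fluoro on this aromatic carbon, meta to a large group, leaves the read-out where it was, so adding a fluoro to the benzyl ring does not bring a gain on its own. The large step of a 23-fold lower number from compound 1 to compound 3 (1.36 log units; beyond the scatter) therefore depends on which carbon carries the fluoro, not only on the fluoro being present: with the same group on different carbons, compound 3 gives 3000 nM and compound 4 gives 50000 nM. Nothing available explains why the choice of carbon matters so much in this series.

The compounds shown leave open whether the gain belongs to fluoro alone or would survive with a chloro, a methoxy or an amine on the carbon that carries the fluoro in compound 3. They also leave open how a fluoro would behave on the carbon that carries the bromo in compound 2, and whether the gain seen with compound 3 would hold if an amide replaced the ester that links the benzyl ring to the rest of the shared core.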